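Swapping acetamido for nitro on the shared core

The source may report more compounds than this note shows. Statements on the series, on what has been measured and on what is new or still open speak of the compounds shown alone.

The study measured three compounds in an ADME assay on L02 cells (Homo sapiens) for antiproliferative activity, read by MTT assay, with a stated time of 48 h; on this read-out lower numbers stand for stronger inhibition and higher numbers for weaker inhibition. Compound 1 `N#CC1=C(N)Oc2c(N)cc3nc4ccccc4nc3c2C12C(=O)N(Cc1cnnn1-c1ccc(F)cc1)c1ccccc12` reaches only a limit in this assay, at > 50000 nM. Compound 2 `N#CC1=C(N)Oc2c(N)cc3nc4ccccc4nc3c2C12C(=O)N(Cc1cnnn1-c1cccc(C(F)(F)F)c1)c1ccccc12` gives 38100 nM in this assay. Compound 3 `CC(=O)Nc1ccc(-n2nncc2CN2C(=O)C3(C(C#N)=C(N)Oc4c(N)cc5nc6ccccc6nc5c43)c3ccccc32)cc1` likewise reaches only a limit in this assay, at > 50000 nM. Two of the three values thus sit at the same limit, as the limit of > 50000 nM in this assay, at which 2 of the 3 values shown sit, shows. The step of an at least 1.3-fold lower number from compound 1 to compound 2 (0.11 log units; that floor lies within the scatter) and the step of an at least 1.3-fold higher number from compound 2 to compound 3 (0.11 log units; that floor lies within the scatter) both have floors within the scatter, while the step that the two limits leave unreadable from compound 1 to compound 3 cannot be read at all.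

Compound 4 `N#CC1=C(N)Oc2c(N)cc3nc4ccccc4nc3c2C12C(=O)N(Cc1cnnn1-c1ccc([N+](=O)[O-])cc1)c1ccccc12` has not yet been measured in this assay. It differs from compound 3 by nitro in place of acetamido on an aromatic carbon. Among the measured compounds shown here, none of the measured steps moves any compound clearly away from the weak end of this assay, so no step beyond the scatter is expected in this assay from this change. Compound 4 is therefore expected to give about 45000 nM in this assay, between 20000 nM and 100000 nM, which means an expected step of an at least 1.1-fold lower number from compound 3 to compound 4 (0.04 log units; that floor lies within the scatter).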

Compound 4, half-maximal inhibitory concentration: > 50000 nM
Compound 4: only a limit was reported; the forecaster's own chance of this, stated with the estimate: 60%; middle value at least 1.1-fold (0.04 log units) from the limit.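

Replacing acetamido with nitro on the aromatic carbon para to a large group removes the hydrogen-bond donor there, yet the new compound still gives no number inside the range of this assay: the limit of > 50000 nM in this assay, at which 3 of the 4 values shown sit. The steps from compound 1 and from compound 3 to compound 4 join limit to limit and cannot be read. Among the compounds shown here, the one readable step is an at least 1.3-fold higher number from compound 2 to compound 4 (0.11 log units; that floor lies within the scatter), so compound 4 is not clearly separated from compound 2.

From the compounds shown here alone, the true values of compound 1, compound 3 and compound 4 remain unknown, so their three groups cannot be ranked against one another. Going by these compounds, it also remains open whether an amine or a carboxylic acid at this place would give a number inside the range of this assay.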